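The compounds below may be only part of what the source reports. "The series", "measured", "known", "first", "only" and "open" are said of these compounds alone.

Two compounds of this series carry the same shared core, seen in compound 1 `O=C(NC(=S)n1ccc2c(OCCCCCOc3ccc(Cl)cc3)cccc21)c1ccccc1` and compound 2 `O=C(NC(=S)N1CCc2c(OCCCCCOc3ccc(Cl)cc3)cccc21)c1ccc(Br)cc1`. In an ADME assay on Huh-7 cells (Homo sapiens) for cytotoxicity (a higher number here means that more compound is tolerated, a lower number that less compound is tolerated), compound 1 gives 29500 nM, and in this assay compound 2 gives 29100 nM; the two values lie within the scatter of each other, so compound 2 stands level with compound 1 rather than apart from it. Compound 3 `O=C(NC(=S)N1CCc2c(OCCCCCOc3ccc(Cl)cc3)cccc21)c1ccc2ccccc2c1` differs from compound 2 in one place: naphthalen-2-yl in place of 4-bromophenyl on a carbonyl carbon. For the measured compounds named here, no measured pair shows this change, so an estimate for compound 3 can rest only on the two values shown. Compound 3 is expected to give 24000 nM, within a range of 9000 nM to 60000 nM. The step of a 1.2-fold lower number from compound 2 to compound 3 (0.08 log units; within the scatter) is therefore estimated to stay within the scatter or to fall slightly.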

Compound 3, half-maximal cytotoxic concentration: > 50000 nM
Compound 3 ended at the assay's limit; the forecaster's own chance of this, stated with the estimate: 10%; at least 2.0-fold (0.31 log units) between middle value and limit.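

Compound 3 reads > 50000 nM in this assay, which is a limit of the assay and not a number. Naphthalen-2-yl in place of 4-bromophenyl on the carbonyl carbon thus gives the first step read at this position, an at least 1.7-fold higher number from compound 2 to compound 3 (0.23 log units; that floor lies within the scatter). The two-ring group brings no fall here, but only a floor can be read, and it rests on the assay's limit: the limit of > 50000 nM in this assay, at which 1 of the 3 values shown sits.

On these data alone, what stays open is how far the true value lies past that limit. Also open, as far as these compounds go, is how a group carrying an amine or a carboxylic acid would read at this carbonyl carbon.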